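A few compounds are considered here, and "the series" means these few. Any claim that something is new, unique, unknown or untested is made for them only; others in the source may bear on it.

Two compounds have been examined in a toxicity assay on the whole organism (strain Icem-CET (SPF Caw)) for cytotoxicity, with Mus musculus as the target; on this read-out lower numbers stand for an effect already at smaller amounts and higher numbers for an effect only at larger amounts of compound. Compound 1, `C#CCNC(=O)/C(C)=C(\C)c1ccccc1`, gives 400 mg/kg in this assay. Compound 2, `C=CCNC(=O)/C(C)=C(\C)c1ccc(C)cc1`, gives 170 mg/kg in this assay. For the measured compounds named here, of the two numbers, compound 2 stands lowest, with compound 1 the only neighbour at a higher number, and that gap lies beyond the scatter of this assay. Going by the values given here, no single-point step between measured compounds is available, so the pair shows only what its two values show. Compound 3, `C=CCNC(=O)/C(C)=C(\C)c1ccccc1`, is not yet measured; it differs from compound 2 by hydrogen in place of methyl on an aromatic carbon. Among the compounds with values here, with no comparable step to lean on, a modest shift toward a higher number, or none beyond the scatter, is expected in this assay, and the step from compound 2 to compound 3 is estimated as a 1.5-fold higher number from compound 2 to compound 3 (0.17 log units; within the scatter). For compound 3 the expected value in this assay is 250 mg/kg, between 120 mg/kg and 500 mg/kg.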

Compound 3, dose for half-maximal effect: 300 mg/kg
Compound 3: middle estimate off by 1.2-fold (0.08 log units), on the low side; the measured number falls inside the stated range.
By their numbers in this assay, from the lowest: compounds 2, 3 and 1 (each within the scatter of the next, the first and the last beyond it).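

For the compounds shown here, for the first time, this assay can be read across a single place. Hydrogen in place of methyl on an aromatic carbon, para to a large group, gives a 1.8-fold higher number from compound 2 to compound 3 (0.25 log units; within the scatter) and so leaves this position with no effect of the methyl that stands clear of the scatter. The other place, on the saturated chain carbon bound to an amide-type nitrogen, behaves no differently: vinyl in place of ethynyl gives a 1.3-fold lower number from compound 1 to compound 3 (0.12 log units; within the scatter) and likewise separates nothing beyond the scatter.

On these data alone, how a methoxy group, a chlorine atom or an amine at the aromatic position would read stays open, as does a propyl group or a longer chain on the amide nitrogen. Nothing measured bears on what lies behind either step.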